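Furan in Place of Iodine on a Nucleoside Core

The compounds below may be only part of what the source reports. "The series", "measured", "known", "first", "only" and "open" are said of these compounds alone.

Of the compounds shown here, three with a shared sugar-bearing core have been tested in a functional assay on CCRF-CEM cells (Homo sapiens), read by MTT assay, with a stated time of 72 h; on this read-out lower numbers stand for stronger inhibition and higher numbers for weaker inhibition. Compound 1 `COc1ncnc2c1c(-c1cccs1)cn2[C@@H]1O[C@H](CO)[C@@H](O)[C@H]1O` gives 90 nM. Compound 2 `Nc1nc2c(c(-c3ccsc3)cn2[C@@H]2O[C@H](CO)[C@@H](O)[C@H]2O)c(=O)[nH]1` reaches only the assay limit, > 20000 nM, so no number is known for it. Compound 3 `Cc1nc(N)c2c(I)cn([C@@H]3O[C@H](CO)[C@@H](O)[C@H]3O)c2n1` gives 9030 nM, the highest of the two numbers shown; its nearest neighbour is compound 1, whose number is markedly lower, a gap well beyond the scatter of repeated measurements. Compound 2 sits at the limit of > 20000 nM in this assay, at which 1 of the 3 values shown sits.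

The step now followed leads from compound 3 to compound 4 `Cc1nc(N)c2c(-c3ccco3)cn([C@@H]3O[C@H](CO)[C@@H](O)[C@H]3O)c2n1`, which is not yet measured. The change is furan-2-yl in place of iodo on an aromatic carbon. Going by the values given here, compound 1, the only potent compound here, also carries a five-membered aromatic ring with 1 hetero atom on its core, although it differs from compound 4 in other places as well, so its value can only hint at the direction.

A move towards stronger inhibition is expected from compound 3 to compound 4, of about a 6.0-fold lower number from compound 3 to compound 4 (0.78 log units; beyond the scatter). Compound 4 is therefore estimated at 1500 nM, within a range from 200 nM to 10000 nM.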

Compound 4, half-maximal inhibitory concentration: > 100000 nM
Compound 4: no number, only a limit; the forecaster's own chance of this, stated with the estimate: 10%; middle value at least 66-fold (1.82 log units) away from the limit.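

In this assay, furan-2-yl in place of iodo on this aromatic carbon gives an at least 11-fold higher number from compound 3 to compound 4 (1.04 log units; beyond the scatter), so what sits at this position, two ring bonds from the ring nitrogen, matters greatly for inhibition on this core. The value of compound 4 is a limit of the assay and not a number: the limit of > 100000 nM in this assay, at which 1 of the 4 values shown sits.
A five-membered aromatic ring with 1 hetero atom at this place therefore does not by itself bring strong inhibition on this core, and compound 1, which also carries such a ring, differs from compound 4 in other places too, so the two cannot be set directly against each other.

The compounds shown cannot tell whether the loss goes with the whole ring or with its oxygen, and a phenyl ring, a methyl group or an amine on the same carbon would help to separate these possibilities. They also leave open whether the same exchange of iodo for furan-2-yl would have a similar result on the core of compound 1.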